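Swapping a piperazine amide for a dioxopiperidine amide

A few compounds are considered here, and "the series" means these few. Any claim that something is new, unique, unknown or untested is made for them only; others in the source may bear on it.

Measured compounds:
Compound 1, `CC(C)(C)NC(=O)c1c(N)sc(-c2ccc(Cl)cc2)c1-c1ccc(Cl)cc1`: 8850 nM
Compound 2, `Nc1sc(-c2ccc(Cl)cc2)c(-c2ccc(Cl)cc2)c1C(=O)N1CCNCC1`: 1020 nM
Compound 3, `CN1CCN(C(=O)c2c(N)sc(-c3ccc(Cl)cc3)c2-c2ccc(Cl)cc2)CC1`: 590 nM

In a functional assay on A549 cells (Homo sapiens) for inhibition, read by sulforhodamine B assay, with a stated time of 72 h (a higher number here means a weaker inhibitor, a lower number a stronger inhibitor), compound 3 shows the lowest number of the three, although compound 2 sits within the scatter of it, so the two cannot be ranked. Compound 1 is clearly apart: a 15-fold lower number from compound 1 to compound 3 (1.18 log units; beyond the scatter) and an 8.7-fold lower number from compound 1 to compound 2 (0.94 log units; beyond the scatter) both go well beyond the scatter, whereas a 1.7-fold lower number from compound 2 to compound 3 (0.24 log units; within the scatter) does not.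

Compound 4, `Nc1sc(-c2ccc(Cl)cc2)c(-c2ccc(Cl)cc2)c1C(=O)N1CCC(=O)CC1=O`, differs from compound 3 at one place: 2,4-dioxopiperidin-1-yl in place of 4-methylpiperazin-1-yl on a carbonyl carbon. For the measured compounds named here, no measured step covers this change. Going by the values given here, the two cyclic amides so far, compound 2 and compound 3, both gave much lower numbers than the open-chain amide of compound 1, and the ring group in compound 4 is again cyclic but carries two carbonyls in place of the ring amine nitrogen, a feature no measured compound has. The expectation is therefore uncertain and leans toward a higher number than compound 3, by roughly a 4.2-fold higher number from compound 3 to compound 4 (0.63 log units; beyond the scatter), with a wide range. Compound 4 is estimated at 2500 nM, between 500 nM and 12000 nM.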

Compound 4, half-maximal inhibitory concentration: 4090 nM
Compound 4: the middle estimate sits 1.6-fold (0.21 log units) below what was measured, within the range that was stated.
By their numbers in this assay, from the lowest: compounds 3 and 2 (each within the scatter of the next); then compound 4; then compound 1.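

In this assay, the 2,4-dioxopiperidin-1-yl group gives up much of what the piperazine rings gained on this carbonyl carbon, with a 6.9-fold higher number from compound 3 to compound 4 (0.84 log units; beyond the scatter) and a 4.0-fold higher number from compound 2 to compound 4 (0.60 log units; beyond the scatter), so a ring on the amide is not enough on its own to reach the low numbers of compound 2 and compound 3. The ring in compound 4 still keeps a smaller advantage over the open-chain (tert-butyl)amino amide, with a 2.2-fold lower number from compound 1 to compound 4 (0.34 log units; beyond the scatter), so the choice of ring matters at this position. Nothing measured here gives a reason for these differences.

The compounds shown leave open whether the ring amine nitrogen or the two carbonyls account for the change; a plain piperidine amide, which has neither, would help separate them. They also leave open how an open chain ending in a dimethylamino group would compare with these rings.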